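A morpholin-4-yl swap in a small series

The compounds below may be only part of what the source reports. "The series", "measured", "known", "first", "only" and "open" are said of these compounds alone.

Measured in a functional assay on HOS cells (Homo sapiens) for inhibition, read by MTT assay, with a stated time of 72 h; a higher number here means a weaker inhibitor, a lower number a stronger inhibitor:
compound 1 `O=C(CCC(=O)OCCCCCCSc1ccc([N+](=O)[O-])c2nonc12)Nc1ccccc1F` gives 2350 nM
compound 2 `O=C(CCC(=O)OCCCCCCSc1ccc([N+](=O)[O-])c2nonc12)Nc1ccc(Br)cc1` gives 2160 nM
compound 3 `COc1ccc(NC(=O)CCC(=O)OCCCCCCSc2ccc([N+](=O)[O-])c3nonc23)cc1` gives 1800 nM

These values lie within the scatter of one another, so compound 3 at 1800 nM cannot be told apart from the other two. Compound 4 `O=C(CCC(=O)N1CCOCC1)OCCCCCCSc1ccc([N+](=O)[O-])c2nonc12` has morpholin-4-yl in place of (4-methoxyphenyl)amino on a carbonyl carbon, a difference that reads morpholin-4-yl in place of (4-methoxyphenyl)amino on a carbonyl carbon in full. The closest measured evidence is a 1.3-fold lower number from compound 1 to compound 3 (0.12 log units; within the scatter) and a 1.2-fold lower number from compound 2 to compound 3 (0.08 log units; within the scatter), both within the scatter. Those steps only exchange groups on the phenyl, and none removes that ring, so they fix no direction. Only a small move is expected, with a 1.4-fold higher number from compound 3 to compound 4 (0.14 log units; within the scatter) as the estimated step. For compound 4 the estimated value is 2500 nM, with an expected range from 900 nM to 7000 nM.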

Compound 4, half-maximal inhibitory concentration: 1010 nM
Compound 4: middle estimate off by 2.5-fold (0.39 log units), on the high side; low and high end bracket the measured number.
By their numbers in this assay, from the lowest: compounds 4, 3, 2 and 1 (each within the scatter of the next, the first and the last beyond it).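

In this assay, the carbonyl carbon keeps its activity when the aromatic ring and the amide hydrogen both leave with the arylamino group, which the phenyl exchanges could not show. Morpholin-4-yl gives a 1.8-fold lower number from compound 3 to compound 4 (0.25 log units; within the scatter) and a 2.1-fold lower number from compound 2 to compound 4 (0.33 log units; beyond the scatter) and a 2.3-fold lower number from compound 1 to compound 4 (0.37 log units; beyond the scatter), so only the last two steps, both modest, pass the scatter. Nothing available explains this result. From the compounds shown here alone, whether a piperidin-1-yl group, an open-chain dimethylamino group or a free carboxylic acid would read the same at this carbonyl carbon stays open. So does the effect of a shorter or longer chain with morpholin-4-yl in place.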